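The source may report more compounds than this note shows. Statements on the series, on what has been measured and on what is new or still open speak of the compounds shown alone.

In a functional assay on PC-3 cells (Homo sapiens) for cytotoxicity, read by MTT assay, with a stated time of 72 h (on this read-out higher numbers stand for weaker inhibition of growth and lower numbers for stronger inhibition of growth), three compounds have been measured so far:

compound 1 `O=C(/N=C(/NC(=O)c1cc(-c2ccccc2)nc2ccccc12)[Se]Cc1ccccc1)c1cc(-c2ccccc2)nc2ccccc12` gives 39300 nM;
compound 2 `CS/C(=N\C(=O)c1cc(-c2ccccc2)nc2ccccc12)NC(=O)c1cc(-c2ccccc2)nc2ccccc12` gives 7480 nM;
compound 3 `CS/C(=N\C(=O)c1cnc2ccccc2c1)NC(=O)c1cnc2ccccc2c1` gives 76300 nM.

Compound 2 and compound 1 share one core and differ in a single place: a group of 8 heavy atoms (7 carbon, 1 selenium; one six-membered aromatic ring of carbon only) in place of a group of 2 heavy atoms (1 carbon, 1 sulfur; no ring), on a carbon with a double bond to nitrogen. That change made the step of a 5.3-fold higher number from compound 2 to compound 1 (0.72 log units; beyond the scatter), a weakening of growth inhibition. Compound 3 carries a different core; the difference between the two cores is not broken down here. Among the three, compound 3 has the highest number, with compound 1 within the scatter of it and compound 2 well beyond.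

Compound 4 `O=C(/N=C(/NC(=O)c1cnc2ccccc2c1)[Se]Cc1ccccc1)c1cnc2ccccc2c1` has not yet been measured. It differs from compound 3 by a group of 8 heavy atoms (7 carbon, 1 selenium; one six-membered aromatic ring of carbon only) in place of a group of 2 heavy atoms (1 carbon, 1 sulfur; no ring), on a carbon with a double bond to nitrogen, the same change as from compound 2 to compound 1, at the same kind of place. The step from compound 3 to compound 4 is expected to be about a 3.9-fold higher number from compound 3 to compound 4 (0.59 log units; beyond the scatter) in this assay, resting on the measured step of a 5.3-fold higher number from compound 2 to compound 1 (0.72 log units; beyond the scatter). Since compound 3 already has the highest number, compound 4 may come close to the top of what this assay can read, and the result could be reported only as a limit. Compound 4 is expected to give about 300000 nM, most likely between 110000 nM and 800000 nM.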

Compound 4, concentration for 50% growth inhibition: 34800 nM
Estimate against measurement, compound 4: 8.6-fold (0.94 log units) above; measured number below the stated range.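

In this assay, putting the selenium-bearing group with its aromatic ring in place of methylsulfanyl gave a 2.2-fold lower number from compound 3 to compound 4 (0.34 log units; beyond the scatter), a strengthening of growth inhibition, and the same change had weakened growth inhibition on the other core: the same change on two cores in this assay, a 5.3-fold higher number (0.72 log units; beyond the scatter) from compound 2 to compound 1 and a 2.2-fold lower number (0.34 log units; beyond the scatter) from compound 3 to compound 4, 12-fold (1.06 log units) apart, beyond the scatter of two such steps. In these two pairs, then, the size and even the direction of this change do not carry over from one core to the other, and a step measured on one core is a poor guide to the other. Two pairs cannot show which feature of the cores sets the two results apart, and they give no rule for any further core in the series.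

The change swaps sulfur for selenium and adds a ring in a single move, and the compounds shown leave open which of these two parts matters. Methylselanyl or benzylsulfanyl on the same carbon, tested on both cores, would pull the two parts apart.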